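This account rests on a few compounds, and the source may have more. Where it says the series, first, only, none or still open, it means among the compounds named here.

Compound 1 `COc1cc(/C=C/C(=O)c2c(OC)cc(O)c(CC=C(C)C)c2O)ccc1O`: 11800 nM
Compound 2 `COc1cc(O)cc(O)c1C(=O)/C=C/c1ccc(O)cc1`: only a limit, > 50000 nM

In a functional assay on A549 cells (Homo sapiens) for inhibition, read by MTT assay, with a stated time of 72 h (on this read-out higher numbers stand for weaker inhibition and lower numbers for stronger inhibition), compound 1 gives 11800 nM. Compound 2 gives only a limit, > 50000 nM; it sits at the limit of > 50000 nM in this assay, at which 1 of the 2 values shown sits, so no number is known for it. On these data alone, compound 3 `COc1cc(/C=C/C(=O)c2c(O)cc(O)cc2OC)ccc1O` is untested and differs from compound 2 by methoxy in place of hydrogen on an aromatic carbon. Among the compounds with values here, because compound 2 sits at the limit of > 50000 nM in this assay, at which 1 of the 2 values shown sits, no measured step can anchor the change, and a methoxy in place of hydrogen is expected to shift inhibition little, within the scatter. Compound 3 is therefore estimated at 40000 nM, between 15000 nM and 100000 nM. The expected step is an at least 1.2-fold lower number from compound 2 to compound 3 (0.09 log units; that floor lies within the scatter).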

Compound 3, half-maximal inhibitory concentration: > 50000 nM
Compound 3 gave a limit, no number; the forecaster's own chance of this, stated with the estimate: 55%; middle value at least 1.2-fold (0.09 log units) from the limit.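

In this assay, within the data shown here, hydrogen in place of 3-methylbut-2-en-1-yl on an aromatic carbon gives an at least 4.2-fold higher number from compound 1 to compound 3 (0.62 log units; beyond the scatter) and this is the first readable step here, pointing to that chain as a contributor to inhibition in compound 1. The methoxy step cannot be read, since compound 2 and compound 3 both give only a limit: the limit of > 50000 nM in this assay, at which 2 of the 3 values shown sit.

On these data alone, whether a shorter chain such as ethyl, or an amine, could stand in place of 3-methylbut-2-en-1-yl and still give a measurable number stays open. As far as these compounds go, the effect of the methoxy on a compound that gives a real number also stays open.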